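Chloro to fluoro: estimating compound 3

The source may report more compounds than this note shows. Statements on the series, on what has been measured and on what is new or still open speak of the compounds shown alone.

Compound 1 (`COc1cc(C)c(Cl)c2c1C(=O)C=CC2=O`): 20600 nM
Compound 2 (`Cc1cc(O)c2c(c1Cl)C(=O)C=CC2=O`): 15700 nM

Both values come from a functional assay on MCF7 cells (Homo sapiens) for cytotoxicity, read by XTT assay, with a stated time of 24 h (on this read-out lower numbers stand for stronger inhibition and higher numbers for weaker inhibition), and lie within the scatter of each other, so compound 2 at 15700 nM holds no clearly separate place. Compound 3 (`Cc1cc(O)c2c(c1F)C(=O)C=CC2=O`) differs from compound 2 by one change (fluoro in place of chloro on an aromatic carbon), fluoro in place of chloro on an aromatic carbon, para to a hydroxy group. Among the compounds with values here, the only measured step (a 1.3-fold lower number from compound 1 to compound 2 (0.12 log units; within the scatter)) concerns a different group, stayed within the scatter and bears only indirectly on this swap. No step beyond the scatter is therefore expected in this assay for this change. The estimated step is correspondingly small (a 1.3-fold higher number from compound 2 to compound 3 (0.11 log units; within the scatter)). Compound 3 is expected at 20000 nM (range 8000 nM to 50000 nM).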

Compound 3, half-maximal inhibitory concentration: 20300 nM
Compound 3: the middle estimate sits 1.0-fold (0.01 log units) below what was measured; measured number inside the range.
By their numbers in this assay, from the lowest: compounds 2, 3 and 1 (each within the scatter of the next).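

In this assay fluoro in place of chloro on this aromatic carbon, para to a hydroxy group, gives a 1.3-fold higher number from compound 2 to compound 3 (0.11 log units; within the scatter) and so stays within the scatter. Within the data shown here, the earlier step concerned only the group on the oxygen, so this is the first reading at the halogen position itself: here, one halogen can replace the other without a clear shift in the number. Nothing on hand offers an explanation for this result, or shows what the halogen contributes.

As far as these compounds go, whether an amine or a longer chain on this carbon would move the number beyond the scatter remains open. Also open, from the compounds shown here alone, is whether the same swap would behave alike with a methoxy group in place of the hydroxy group.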